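The compounds below may be only part of what the source reports. "The series", "measured", "known", "first", "only" and "open" are said of these compounds alone.

- Compound 1 `NC1CCC(Nc2nc(NCc3ccc(Br)cc3)c3ncn(C4CCCC4)c3n2)CC1`: 1170 nM
- Compound 2 `NC1CCC(Nc2nc(NCc3ccc(-c4cccc(F)c4)cc3)c3ncn(C4CCCC4)c3n2)CC1`: 290 nM

Among the measured compounds shown here, in a functional assay on K562 cells (Homo sapiens) for inhibition, with a stated time of 72 h (on this read-out higher numbers stand for weaker inhibition and lower numbers for stronger inhibition), compound 1 gives 1170 nM, the higher of the two numbers measured so far, which makes it the weaker inhibitor of the pair. Compound 2 gives 290 nM in the same test. Compound 3 `NC1CCC(Nc2nc(NCc3ccc(-c4ccsc4)cc3)c3ncn(C4CCCC4)c3n2)CC1` has not yet been measured. It departs from compound 1 by a single change: thiophen-3-yl in place of bromo on an aromatic carbon. In plain terms, this puts thiophen-3-yl in place of bromo on an aromatic carbon.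

For the measured compounds named here, only one measured step bears on this change: a 4.0-fold lower number from compound 1 to compound 2 (0.61 log units; beyond the scatter). That step also removes the bromo, with 3-fluorophenyl entering in its place, so it is a fair but imperfect guide, since a five-membered ring holding sulfur is not a fluorinated six-membered one. A single step is thin support, so a drop of similar size in this assay is expected, with wide margins. The estimated step is a 3.7-fold lower number from compound 1 to compound 3 (0.56 log units; beyond the scatter). For compound 3 the expected value is 320 nM, with an estimated range from 120 nM to 800 nM.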

Compound 3, half-maximal inhibitory concentration: 150 nM
The estimate for compound 3 lay 2.1-fold (0.33 log units) above the measured number; the range from low to high includes it.
By their numbers in this assay, from the lowest: compounds 3 and 2 (each within the scatter of the next); then compound 1.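

In this assay, thiophen-3-yl now stands with 3-fluorophenyl as a second ring that improves on the bromo, and a 7.8-fold lower number from compound 1 to compound 3 (0.89 log units; beyond the scatter) lies beyond the scatter, so the earlier gain does not depend on one particular ring. The two rings themselves cannot be told apart, since a 1.9-fold lower number from compound 2 to compound 3 (0.29 log units; within the scatter) lies within the scatter: at this place, on an aromatic carbon of a six-membered aromatic ring of carbon only, a five-membered aromatic ring holding sulfur and a six-membered ring carrying fluorine give equivalent numbers. No measurement on these compounds accounts for the advantage of either ring over the bromo.

The compounds shown leave open whether the ring at this place needs to be aromatic at all, a question that a saturated ring such as cyclohexyl or a non-ring group such as a short alkyl chain would address. They also leave open how far the result depends on the ring's atoms and attachment point, which thiophen-2-yl, a pyridine ring or an unsubstituted phenyl would begin to test.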